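A few compounds are considered here, and "the series" means these few. Any claim that something is new, unique, unknown or untested is made for them only; others in the source may bear on it.

Measured so far in an ADME assay on HEK293 cells (Homo sapiens) for cytotoxicity, read by resazurin assay, with a stated time of 48 h; a higher number here means that more compound is tolerated, a lower number that less compound is tolerated:

compound 1 `O=S(=O)(Nc1ccc2oc(-c3ccccc3)nc2c1)c1ccc(Cl)c(C(F)(F)F)c1`: 66000 nM
compound 2 `O=S(=O)(Nc1ccc2oc(-c3ccccc3)nc2c1)c1ccc(Cl)c(Cl)c1`: 71000 nM

Compound 2 stands level with compound 1; the step of a 1.1-fold higher number from compound 1 to compound 2 (0.03 log units; within the scatter) lies within the scatter, so the two numbers are not distinguishable.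

Compound 3 `O=[N+]([O-])c1cc(S(=O)(=O)Nc2ccc3oc(-c4ccccc4)nc3c2)ccc1Cl` carries the change (nitro in place of chloro on an aromatic carbon). Within the data shown here, the only measured step, a 1.1-fold higher number from compound 1 to compound 2 (0.03 log units; within the scatter), swaps one substituent at the same carbon and stays within the scatter; no measured step involves a nitro group. The step of a 1.0-fold lower number from compound 2 to compound 3 (0.02 log units; within the scatter) is therefore expected to stay within the scatter. For compound 3 the expected value is 68000 nM, with a range of 34000 nM to 136000 nM.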

Compound 3, half-maximal cytotoxic concentration: 90000 nM
Estimate against measurement, compound 3: 1.3-fold (0.12 log units) below; low and high end bracket the measured number.
By their numbers in this assay, from the lowest: compounds 1, 2 and 3 (each within the scatter of the next).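

In this assay, nitro at this aromatic carbon, ortho to a chloro group, gives a 1.3-fold higher number from compound 2 to compound 3 (0.10 log units; within the scatter) and a 1.4-fold higher number from compound 1 to compound 3 (0.13 log units; within the scatter), so the three substituents tested here cannot be told apart. The position therefore tolerates a group of three heavy atoms carrying hydrogen-bond acceptors as well as it tolerates chloro, with no separation from trifluoromethyl either. Nothing measured here explains this level behaviour. As far as these compounds go, whether an amine or a carboxylic acid at this carbon would stay level remains open. So does the effect of changes elsewhere on the shared core.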